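Amide nitrogen variation in a series pinned at the limit

A few compounds are considered here, and "the series" means these few. Any claim that something is new, unique, unknown or untested is made for them only; others in the source may bear on it.

Of the compounds shown here, three have been tested in an assay on isolated protein for inhibition of vitamin D3 receptor (Homo sapiens), read by fluorescence polarization; a higher number here means a weaker inhibitor, a lower number a stronger inhibitor. Compound 1 `CS(=O)(=O)c1ccc(C(=O)N2CCC(C(=O)N(Cc3ccccc3)c3ccccc3)CC2)cc1[N+](=O)[O-]` gives > 60000 nM, which is a limit of the assay and not a number. Compound 2 `CS(=O)(=O)c1ccc(C(=O)N2CCC(C(=O)N3CCc4ccccc43)CC2)cc1[N+](=O)[O-]` likewise gives > 60000 nM, again only a limit. Compound 3 `CS(=O)(=O)c1ccc(C(=O)N2CCC(C(=O)N3CCN(c4ccc(F)cc4)CC3)CC2)cc1[N+](=O)[O-]` also gives no more than the limit > 60000 nM. Compound 2 therefore stands at a limit only, and the two other values shown are limits as well; all three sit at the limit of > 60000 nM in this assay, at which 3 of the 3 values shown sit. Among the measured compounds shown here, no pair among the measured compounds differs in a single place, so no measured step within the set can be quoted.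

Compound 4 `CN(Cc1ccccc1)C(=O)C1CCN(C(=O)c2ccc(S(C)(=O)=O)c([N+](=O)[O-])c2)CC1` remains to be measured. It differs from compound 2 by benzyl(methyl)amino in place of 2,3-dihydro-1H-indol-1-yl on a carbonyl carbon. Compound 1 also carries a benzyl group at that amide and returned only a limit. With every reading so far at the limit, the step from compound 2 to compound 4 is expected to be a step that the limit leaves unreadable from compound 2 to compound 4, that is no change beyond the scatter. Compound 4 is expected to give 80000 nM, within a range from 30000 nM to 300000 nM, and most probably again only a limit.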

Compound 4, half-maximal inhibitory concentration: > 60000 nM
Compound 4 ended at the assay's limit; the forecaster's own chance of this, stated with the estimate: 90%; the middle value is on the limit's open side.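

No new step can be read: compound 4 is joined to compound 2 and to compound 1 only through pairs of limits, which give no size. The compounds shown leave open whether any amide group on the shared core gives a readable inhibition value, because every reading rests at one limit: the limit of > 60000 nM in this assay, at which 4 of the 4 values shown sit.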